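A few compounds are considered here, and "the series" means these few. Any claim that something is new, unique, unknown or untested is made for them only; others in the source may bear on it.

Measured so far in a functional assay on A549 cells (Homo sapiens) for cytotoxicity, read by MTT assay, with a stated time of 48 h; a higher number here means a weaker inhibitor, a lower number a stronger inhibitor:
Compound 1 `CCOC(=O)c1c(-c2c(Cl)c3ccccc3oc2=O)nn(-c2ccccc2)c1C(=O)OCC` gives 34000 nM.
Compound 2 `CCOC(=O)c1c(-c2c(Cl)c3ccccc3oc2=O)nn(-c2cccc(C)c2)c1C(=O)OCC` gives 36000 nM.
Compound 3 `CCOC(=O)c1c(-c2cc3ccccc3oc2=O)nn(-c2ccccc2)c1C(=O)OCC` gives 100000 nM.

Compound 4 `CCOC(=O)c1c(-c2cc3ccccc3oc2=O)nn(-c2cccc(C)c2)c1C(=O)OCC` has not yet been measured. It is made from compound 3 by the change (methyl in place of hydrogen on an aromatic carbon). The same change is already known from one measured pair, (methyl in place of hydrogen on an aromatic carbon), where the step was a 1.1-fold higher number from compound 1 to compound 2 (0.02 log units; within the scatter). The two places match word for word, so this is taken as the same change. The cores of compound 1 and compound 3 differ by hydrogen in place of chloro on an aromatic carbon, with a step of a 2.9-fold higher number from compound 1 to compound 3 (0.47 log units; beyond the scatter) in this assay.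

Because the methyl step a 1.1-fold higher number from compound 1 to compound 2 (0.02 log units; within the scatter) stayed within the scatter, the step from compound 3 to compound 4 is expected to be similarly small, a 1.1-fold higher number from compound 3 to compound 4 (0.04 log units; within the scatter). Compound 4 is thus estimated at 110000 nM, likely between 50000 nM and 250000 nM.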

Compound 4, half-maximal inhibitory concentration: 52000 nM
Compound 4: the middle estimate sits 2.1-fold (0.33 log units) above what was measured, within the range that was stated.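

In this assay, methyl in place of hydrogen on the core of compound 3 gave a 1.9-fold lower number from compound 3 to compound 4 (0.28 log units; within the scatter), and this step does not differ meaningfully from the earlier one: the same change on two cores in this assay, a 1.1-fold higher number (0.02 log units; within the scatter) from compound 1 to compound 2 and a 1.9-fold lower number (0.28 log units; within the scatter) from compound 3 to compound 4, 2.0-fold (0.31 log units) apart, within the scatter of two such steps

Hydrogen in place of chloro on the 3-methylphenyl compounds gave a 1.4-fold higher number from compound 2 to compound 4 (0.16 log units; within the scatter), which also agrees with its earlier counterpart: the same change on two cores in this assay, a 2.9-fold higher number (0.47 log units; beyond the scatter) from compound 1 to compound 3 and a 1.4-fold higher number (0.16 log units; within the scatter) from compound 2 to compound 4, 2.0-fold (0.31 log units) apart, within the scatter of two such steps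

The two changes therefore carried between these cores without a difference that can be told from the scatter, but one pair of steps per change does not show that the steps are identical or that they would hold on other cores.

The compounds shown leave open how an amine or a methoxy group would behave in place of the methyl. They also leave open what a carboxylic acid or an amide would do in place of the ethyl esters.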